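The source may report more compounds than this note shows. Statements on the series, on what has been measured and on what is new or still open speak of the compounds shown alone.

Compound 1 `COc1ncnc2c1c(I)cn2[C@@H]1O[C@H](CO)[C@@H](O)[C@H]1O` in a functional assay on A549 cells (Homo sapiens), read by MTT assay, with a stated time of 72 h (a higher number here means a weaker inhibitor, a lower number a stronger inhibitor), gives only a limit, > 20000 nM. Compound 2 `COc1ncnc2c1c(-c1ccccc1)cn2[C@@H]1O[C@H](CO)[C@@H](O)[C@H]1O` in this assay likewise returns a limit, > 20000 nM. Compound 3 `CNc1ncnc2c1c(-c1ccsc1)cn2[C@@H]1O[C@H](CO)[C@@H](O)[C@H]1O` in this assay also stops at a limit, > 20000 nM.

Compound 3 thus stands at the same limit as the other two compounds; none of the three yields a number, so compound 3 cannot be ranked against them. Within the data shown here, the one computed step, a step that the two limits leave unreadable from compound 1 to compound 2, is unreadable. Compound 4 `COc1ncnc2c1c(-c1ccsc1)cn2[C@@H]1O[C@H](CO)[C@@H](O)[C@H]1O` differs from compound 3 in this way: methoxy in place of methylamino on an aromatic carbon. Among the measured compounds shown here, no measured step bears on that change; the only thing known is the limit of > 20000 nM in this assay, at which 3 of the 3 values shown sit, shared by every value shown. Any estimate of a step that the limit leaves unreadable from compound 3 to compound 4 therefore rests on the limit alone. Compound 4 is expected to give 30000 nM, with a range of 10000 nM to 100000 nM, and most likely to be reported once more as a limit.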

Compound 4, half-maximal inhibitory concentration: 5170 nM
Beside the measured number, compound 4's estimate is 5.8-fold (0.76 log units) above it; the whole stated range lies above it.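

In this assay, with thiophen-3-yl held in place, methoxy in place of methylamino on this aromatic carbon gives an at least 3.8-fold lower number from compound 3 to compound 4 (0.58 log units; beyond the scatter), so this position can change the read-out. With methoxy held in place, thiophen-3-yl in place of phenyl gives an at least 3.8-fold lower number from compound 2 to compound 4 (0.58 log units; beyond the scatter), and thiophen-3-yl in place of iodo gives an at least 3.8-fold lower number from compound 1 to compound 4 (0.58 log units; beyond the scatter). Only the pairing of methoxy with thiophen-3-yl, in compound 4, yields a number rather than a limit: the limit of > 20000 nM in this assay, at which 3 of the 4 values shown sit.

On these data alone, the full size of these steps stays open, as compound 1, compound 2 and compound 3 give only limits. Also open, as far as these compounds go, is how an ethoxy or a dimethylamino group in place of methoxy would read.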